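This account rests on a few compounds, and the source may have more. Where it says the series, first, only, none or still open, it means among the compounds named here.

Measured so far in an ADME assay on the whole organism with Oryza sativa as the target, tested at 10 uM; a lower number here means a stronger effect, a higher number a weaker effect of the compound at the concentration tested:
- compound 1, `Cc1ccccc1NC(=O)N[C@@H](C)c1ccccc1`: 99%
- compound 2, `CCc1ccc(NC(=O)N[C@H](C)c2ccccc2)cc1`: 44%
- compound 3, `CCc1ccc(NC(=O)N[C@@H](C)c2ccccc2)cc1`: 91%

Compound 2 gives the lowest of the three numbers in this assay. For the measured compounds named here, its nearest neighbour is compound 3, and the one measured step, a number 47 percentage points higher from compound 2 to compound 3 (beyond the scatter), shows that compound 3 lies well apart from compound 2 beyond the scatter; compound 1 lies furthest from compound 2. Going by the values given here, the only step that has been measured rests on (the fact that compounds 2 and 3 differ only in the configuration as drawn); it concerns no change of substituent.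

Compound 4, `C[C@@H](NC(=O)Nc1ccc(C(C)(C)C)cc1)c1ccccc1`, has not been measured. It differs from compound 2 by tert-butyl in place of ethyl on an aromatic carbon. Among the compounds with values here, no measured step touches a change of this kind, so the measured steps give no direct guide to its size or direction. The expectation for compound 4 in this assay is therefore a step of a number 6 percentage points higher from compound 2 to compound 4 (within the scatter), which is taken as none beyond the scatter. Compound 4 is estimated at 50%, with a range from 28% to 78%.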

Compound 4, a percentage reported as activity, at one concentration (the size of the read-out at that concentration, not a potency): 53%
The estimate for compound 4 lay 3 percentage points below the measured number, and the stated range covers the measured number.
By their numbers in this assay, from the lowest: compounds 2 and 4 (each within the scatter of the next); then compounds 3 and 1 (each within the scatter of the next).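

In this assay, tert-butyl in place of ethyl on an aromatic carbon, para to a large group, gives a number 9 percentage points higher from compound 2 to compound 4 (within the scatter). Until now, this position had not been varied among the compounds compared one change at a time, and the pair shows that, in this assay, the read-out does not separate ethyl from tert-butyl here, even though the entering group is the larger by heavy-atom count. Nothing available accounts for this result, and the only supporting fact concerns a different kind of change.

Going by these compounds, it remains open whether the large difference linked to configuration in the ethyl pair also holds with tert-butyl at this position. Also open, on these data alone, is whether a group of another kind here, such as an amine, a carboxylic acid or a longer chain, would leave the read-out equally unchanged.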